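A few compounds are considered here, and "the series" means these few. Any claim that something is new, unique, unknown or untested is made for them only; others in the source may bear on it.

For the measured compounds named here, in an ADME assay on microsomes from liver (Homo sapiens) for metabolic stability, read by LC-MS, with a stated time of 10 min (a higher number here means that more of the compound is left, a lower number that less of the compound is left), compound 1 `c1cnc2c(c1)CCC[C@@H]2N(CC1CC1)C[C@H]1Cc2c(cccc2N2CCNCC2)CN1` gives 82.1% and holds the only number, so it cannot yet be ranked against any other compound. Compound 2 `Cc1cnc(CN(C)C[C@H]2Cc3c(cccc3N3CCNCC3)CN2)c(C)c1` stands as "not determined" (no result reported) and offers no comparison. Compound 3 `CC(C)N(C[C@H]1Cc2c(cccc2N2CCNCC2)CN1)[C@H]1CCCc2cccnc21` carries isopropyl in place of cyclopropylmethyl on an amine nitrogen and otherwise shares the core of compound 1.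

Going by the values given here, no measured pair shows this exchange, and no trend can be read from a single number. The expectation in this assay therefore rests on one anchor, compound 1 at 82.1% as the starting point, which leaves more room to fall than to rise. No step beyond the usual scatter is expected, only a slight lean downward. The expected step (a number 4.1 percentage points lower from compound 1 to compound 3 (within the scatter)) stays within that scatter. In this assay the estimate for compound 3 is 78% with an expected range from 62% to 92% as the working window.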

Compound 3, percent of the compound remaining: 75%
Estimate against measurement, compound 3: 3 percentage points above; low and high end bracket the measured number.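

In this assay, for the compounds shown here, the replacement of cyclopropylmethyl by isopropyl on an amine nitrogen gives a number 7.1 percentage points lower from compound 1 to compound 3 (within the scatter), the first step that can be read. At this place, on the shared core, the three-membered non-aromatic ring can therefore give way to an open branched group without a step beyond the usual scatter. Neither group carries a hydrogen-bond donor, a hydrogen-bond acceptor or a net charge, so this single pair speaks only for groups made of carbon alone, and no measurement available here offers an explanation for the step.

On these data alone, whether the position stays as undemanding in this assay with a group containing other atoms remains open: a primary amine, a carboxylic acid or a longer chain in place of isopropyl would test this beyond groups of carbon alone. With no result for compound 2, the reading rests on one pair and a single place, so it leaves open whether the same exchange would behave alike on a different core or how changes elsewhere on the shared core would compare.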